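Swapping the Bromophenyl Thioether for a Difluorophenyl One

The compounds below may be only part of what the source reports. "The series", "measured", "known", "first", "only" and "open" are said of these compounds alone.

The compounds measured so far:
compound 1, `COc1ccc(-c2nc(CSc3cccc(Br)c3)nc3ccsc23)cn1`: > 50000 nM
compound 2, `COc1ccc(-c2nc(/C=C\c3cccc(Cl)c3)nc3ccsc23)cn1`: 53000 nM
compound 3, `COc1ccc(-c2nc(CSc3cccc(C(F)(F)F)c3)nc3ccsc23)cn1`: > 50000 nM

In an ADME assay on cells (Homo sapiens) for cytotoxicity, read by resazurin assay, with a stated time of 5 days (a lower number here means that less compound is tolerated, a higher number that more compound is tolerated), compound 1 gives > 50000 nM, which is a limit of the assay and not a number. Compound 3 likewise gives > 50000 nM, again a limit. Compound 2 gives 53000 nM. Within the data shown here, the one step between compounds that differ in a single place, a step that the two limits leave unreadable from compound 1 to compound 3, is therefore unreadable, and the picture of the series is set by the limit of > 50000 nM in this assay, at which 2 of the 3 values shown sit. All that can be said of compound 1 is that it stands at that limit.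

Compound 4 is `COc1ccc(-c2nc(CSc3ccc(F)cc3F)nc3ccsc23)cn1`. It differs from compound 1 by 2,4-difluorophenyl in place of 3-bromophenyl on a sulfur. Among the measured compounds shown here, no measured step has a readable size that bears on this change, and the only step from compound 1, a step that the two limits leave unreadable from compound 1 to compound 3, tells nothing of direction. With every value shown sitting at or close to the limit, the expectation for compound 4 is no step beyond the scatter, and most likely another limit rather than a number. Compound 4 is estimated at 60000 nM, with a range from 30000 nM to 150000 nM. The expected step that the limit leaves unreadable from compound 1 to compound 4 is accordingly expected to lie within the scatter.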

Compound 4, half-maximal cytotoxic concentration: > 50000 nM
Compound 4: only a limit was reported; the forecaster's own chance of this, stated with the estimate: 75%; the middle value is on the limit's open side.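

In this assay compound 4 gives > 50000 nM, which is a limit of the assay and not a number. Among these compounds, compound 1 also stands at a limit, so no step between compound 1 and compound 4 can be read. The compounds shown leave open whether compound 1, compound 3 and compound 4 differ at all in this assay, as their values give no numbers to compare: the limit of > 50000 nM in this assay, at which 3 of the 4 values shown sit.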